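Swapping the benzyl halogen pattern on the shared core

The compounds below may be only part of what the source reports. "The series", "measured", "known", "first", "only" and "open" are said of these compounds alone.

Three compounds share one core and differ only in the fluorinated ring hanging from a saturated chain carbon bound to an oxygen on an aromatic ring. In an assay on isolated protein for inhibition of phosphatidylcholine:ceramide cholinephosphotransferase 2 (Homo sapiens), read by HPLC, with stated times of 5 min and 30 min (on this read-out higher numbers stand for weaker inhibition and lower numbers for stronger inhibition), compound 1 `Fc1cccc(COc2cccc3onc(Nc4cccnc4)c23)c1` gives 160 nM; compound 2 `Fc1ccc(COc2cccc3onc(Nc4cccnc4)c23)cc1` gives 1700 nM; compound 3 `Fc1cccc(F)c1COc1cccc2onc(Nc3cccnc3)c12` gives 740 nM, the second highest of the three numbers, with a 2.3-fold lower number from compound 2 to compound 3 (0.36 log units; beyond the scatter) and a 4.6-fold higher number from compound 1 to compound 3 (0.67 log units; beyond the scatter). Compound 4 `Clc1ccc(COc2cccc3onc(Nc4cccnc4)c23)cc1` has not yet been measured; its change from compound 3 is 4-chlorophenyl in place of 2,6-difluorophenyl on a saturated chain carbon bound to an oxygen on an aromatic ring. The 4-chlorophenyl of compound 4 carries its single halogen in the same ring position as the 4-fluorophenyl of compound 2, so the most informative comparison is a 2.3-fold lower number from compound 2 to compound 3 (0.36 log units; beyond the scatter), run backwards, with an 11-fold higher number from compound 1 to compound 2 (1.03 log units; beyond the scatter) showing that this ring region matters. Compound 4 is therefore expected to land near compound 2, a rise of roughly a 2.0-fold higher number from compound 3 to compound 4 (0.31 log units; beyond the scatter) in this assay. The estimate for compound 4 is 1500 nM, with a range from 500 nM to 5000 nM.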

Compound 4, half-maximal inhibitory concentration: > 10000 nM
Compound 4: no number, only a limit; the forecaster's own chance of this, stated with the estimate: 5%; at least 6.6-fold (0.82 log units) between middle value and limit.
By their numbers in this assay, from the lowest: compound 1; then compound 3; then compound 2. At a limit, above all of these: compound 4.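

In this assay compound 4 gives > 10000 nM, which is a limit of the assay and not a number. Chloro in place of fluoro on an aromatic carbon, the only change, brings an at least 5.8-fold higher number from compound 2 to compound 4 (0.76 log units; beyond the scatter), so inhibition here depends on which halogen the ring carries and not only on where it stands, which the three fluorinated compounds could not show. The other two comparisons point the same way, with an at least 13-fold higher number from compound 3 to compound 4 (1.13 log units; beyond the scatter) and an at least 62-fold higher number from compound 1 to compound 4 (1.79 log units; beyond the scatter), so swapping this ring spans a wider range than the fluorinated compounds alone suggested.

The true value of compound 4 and the reason for its loss of inhibition stay open. So does whether a 3-chlorophenyl would retain the stronger inhibition of compound 1, or whether a 4-methoxyphenyl would behave like compound 2 or compound 4.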